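This account rests on a few compounds, and the source may have more. Where it says the series, first, only, none or still open, it means among the compounds named here.

Measured in a functional assay on the whole organism with Scenedesmus acutus as the target; a lower number here means a stronger inhibitor, a higher number a weaker inhibitor:
- compound 1 `CC(C)OC(=O)c1cc(N2C(=O)C3=C(CCCC3)C2=O)ccc1Cl`: 1000 nM
- compound 2 `CC(C)OC(=O)c1cc(N2C(=O)C3=C(CCCC3)C2=O)c(F)cc1Cl`: 57.5 nM
- compound 3 `CCCCCCCCOC(=O)c1cc(N2C(=O)C3=C(CCCC3)C2=O)ccc1Cl`: > 100000 nM (a limit of the assay, not a number)

Of the two true numbers, compound 1 has the higher, 1000 nM. For the measured compounds named here, its only numerical neighbour lies well away, a 17-fold lower number from compound 1 to compound 2 (1.24 log units; beyond the scatter).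

Compound 4 `C#CCOc1cc(N2C(=O)C3=C(CCCC3)C2=O)ccc1Cl` is not yet measured. The change is propargyloxy in place of isopropoxycarbonyl on an aromatic carbon, ortho to a chloro group.

Going by the values given here, no measured step makes this exact change. The nearest is an at least 100-fold higher number from compound 1 to compound 3 (2.00 log units; beyond the scatter), a change within the isopropoxycarbonyl group that is large and runs towards a higher number with the longer chain. It shows that this assay responds strongly to the group at this place, so a step beyond the scatter is more likely than none. The step of a 17-fold lower number from compound 1 to compound 2 (1.24 log units; beyond the scatter) is also large, but it leaves the isopropoxycarbonyl group untouched and says little here beyond the range of sizes the series can show.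

The shorter propargyloxy group points, weakly, towards a lower number, and a moderate step in that direction is expected. The expected step is a 3.3-fold lower number from compound 1 to compound 4 (0.52 log units; beyond the scatter). For compound 4 the estimated value is 300 nM, with an expected range of 40 nM to 2500 nM.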

Compound 4, half-maximal inhibitory concentration: 79.4 nM
Estimate against measurement, compound 4: 3.8-fold (0.58 log units) above, and the stated range covers the measured number.
By their numbers in this assay, from the lowest: compounds 2 and 4 (each within the scatter of the next); then compound 1. At a limit, above all of these: compound 3.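

Before compound 4, the only change at this aromatic carbon, ortho to a chloro group, was the octyl chain of compound 3, and that ended at a limit of the assay, not a number. For the compounds shown here, compound 4 gives the first true number for a change at this place: in this assay the whole isopropoxycarbonyl group, carbonyl included, can give way to propargyloxy, with fewer heavy atoms, and a 13-fold lower number from compound 1 to compound 4 (1.10 log units; beyond the scatter) follows with the number falling, not rising. Which part of this exchange carries the step cannot be told, and nothing measured here gives a cause for it.

A propoxy or allyloxy group at the same place would separate the triple bond from the loss of the carbonyl, and a longer alkynyloxy chain would test whether the response to chain length seen with octyl also holds for this oxygen-linked series. Going by these compounds, it also remains open whether the fluoro change, read only as a 17-fold lower number from compound 1 to compound 2 (1.24 log units; beyond the scatter) with isopropoxycarbonyl in place, carries over to a compound bearing propargyloxy.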